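A few compounds are considered here, and "the series" means these few. Any claim that something is new, unique, unknown or untested is made for them only; others in the source may bear on it.

In a toxicity assay on THP-1 cells (Homo sapiens) for inhibition (on this read-out lower numbers stand for higher toxicity in this test and higher numbers for lower toxicity in this test), compound 1 `Cn1c(-c2ccccc2)cnc1NC(=O)c1ccc(F)cc1` gives > 100000 nM, which is a limit and not a number. Compound 2 `Cn1c(-c2ccccc2F)cnc1NC(=O)c1ccc(F)cc1` gives > 100000 nM, also a limit. Compound 3 `Cn1c(-c2ccc(Cl)cc2)cnc1NC(=O)c1ccc(F)cc1` gives a true number, 37000 nM. Compound 1 therefore stands at the limit of > 100000 nM in this assay, at which 2 of the 3 values shown sit.

Compound 4 `Cn1c(-c2ccccc2)cnc1NC(=O)c1ccccc1` carries hydrogen in place of fluoro on an aromatic carbon, turning 4-fluorophenyl into phenyl. The measured steps all alter the other phenyl group, so they guide only loosely. Adding fluoro there gave a step that the two limits leave unreadable from compound 1 to compound 2. Adding chloro gave an at least 2.7-fold lower number from compound 1 to compound 3 (0.43 log units; beyond the scatter), and swapping groups gave an at least 2.7-fold lower number from compound 2 to compound 3 (0.43 log units; beyond the scatter). Those readable drops came with an added chloro, which compound 4 lacks, so no step beyond the scatter is expected. The estimate means a number no higher from compound 1 to compound 4 (the limit leaves the size open). Compound 4 is expected near 100000 nM, with an estimated range of 50000 nM to 200000 nM.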

Compound 4, half-maximal cytotoxic concentration: > 100000 nM
Compound 4: no number, only a limit; the forecaster's own chance of this, stated with the estimate: 75%; the middle value lies on the limit itself.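

The step from compound 1 to compound 4 cannot be read, since each gives only a limit and not a number: the limit of > 100000 nM in this assay, at which 3 of the 4 values shown sit.

As far as these compounds go, whether hydrogen in place of fluoro changes the result in this assay at all stays open.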